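This account rests on a few compounds, and the source may have more. Where it says the series, first, only, none or still open, it means among the compounds named here.

Compound 1 `Cn1c(=O)c(C(=O)Nc2ccc(F)cc2F)cc2cnc(Nc3ccc4[nH]ccc4c3)nc21` gives 5000 nM in a functional assay on K562 cells (Homo sapiens) for inhibition, read by trypan blue exclusion, with a stated time of 72 h; on this read-out lower numbers stand for stronger inhibition and higher numbers for weaker inhibition. Compound 2 `Cn1c(=O)c(S(=O)(=O)Cc2ccc(F)cc2)cc2cnc(Nc3ccc4[nH]ccc4c3)nc21` gives 30000 nM in this assay. Compound 3 `Cn1c(=O)c(S(=O)(=O)c2ccc(O)cc2)cc2cnc(Nc3ccc4[nH]ccc4c3)nc21` gives 100 nM in this assay.

Compound 3 stands lowest of the three numbers, and both of its steps, a 50-fold lower number from compound 1 to compound 3 (1.70 log units; beyond the scatter) and a 300-fold lower number from compound 2 to compound 3 (2.48 log units; beyond the scatter), are beyond the scatter, so it is the strongest inhibitor of the group in this assay. Compound 4 `Cn1c(=O)c(S(=O)(=O)c2ccc([N+](=O)[O-])cc2F)cc2cnc(Nc3ccc4[nH]ccc4c3)nc21` has not yet been measured. It differs from compound 3 in one place: 2-fluoro-4-nitrophenyl in place of 4-hydroxyphenyl on a sulfonyl sulfur. The step that bears most directly on this change is a 300-fold lower number from compound 2 to compound 3 (2.48 log units; beyond the scatter), where the group on the sulfonyl sulfur was also exchanged, although that exchange altered two things at once, the chain and the ring substituent. The step of a 50-fold lower number from compound 1 to compound 3 (1.70 log units; beyond the scatter) touches the same region, with a different group leaving. In both, the arrival of the 4-hydroxyphenyl group brought a large fall in the number; its departure in compound 4 is therefore expected to reverse part of that, giving a higher number, beyond the scatter. Compound 4 is thus estimated at 1500 nM, between 300 nM and 10000 nM, which would mean an expected step of a 15-fold higher number from compound 3 to compound 4 (1.18 log units; beyond the scatter).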

Compound 4, half-maximal inhibitory concentration: 200 nM
For compound 4 the middle estimate is 7.5-fold (0.88 log units) above the measured one; the whole stated range lies above it.
By their numbers in this assay, from the lowest: compounds 3 and 4 (each within the scatter of the next); then compound 1; then compound 2.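

In this assay, the exchange on the sulfonyl sulfur gives a 2.0-fold higher number from compound 3 to compound 4 (0.30 log units; within the scatter), so the hydroxyl-bearing ring that looked special in compound 3 can be replaced by 2-fluoro-4-nitrophenyl, which has no hydrogen-bond donor and more heavy atoms, with no change beyond the scatter. The other new step, a 150-fold lower number from compound 2 to compound 4 (2.18 log units; beyond the scatter), shows a second aromatic group on the sulfonyl sulfur standing far from 4-fluorobenzyl, so among the sulfonyl compounds here the low numbers belong to compound 3 and compound 4, while compound 2 goes against any idea that the sulfonyl group alone is enough. No measurement shown here explains why these two different rings give values within the scatter of each other.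

The fluorine and the nitro group arrive together, so the part played by each one remains unresolved, as does the part played by the hydroxyl group in compound 3. From the compounds shown here alone, it also remains open whether a plain phenyl, a 4-aminophenyl or a 4-carboxyphenyl group on the sulfonyl sulfur would keep the number as low as in compound 3 and compound 4.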